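The compounds below may be only part of what the source reports. "The series", "measured", "known", "first", "only" and "open" are said of these compounds alone.

Measured so far:
compound 1, `CC(C)c1ccc(Nc2ccc3c(OCCCN4CCN(C)CC4)cccc3n2)cc1`, 1890 nM
compound 2, `CN1CCN(CCCOc2cccc3nc(Nc4ccc(F)c(F)c4)ccc23)CC1`, 1080 nM

Both values come from a functional assay on SK-MEL-28 cells (Homo sapiens) for inhibition, read by sulforhodamine B assay, with a stated time of 48 h; on this read-out higher numbers stand for weaker inhibition of growth and lower numbers for stronger inhibition of growth. For the measured compounds named here, compound 2 has the lowest of the two numbers; its only neighbour is compound 1, and the step of a 1.8-fold lower number from compound 1 to compound 2 (0.24 log units; within the scatter) does not separate the two beyond the scatter, so neither can be called the stronger.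

Compound 3, `CN1CCN(CCCOc2cccc3nc(Nc4cc(Cl)cc(Cl)c4)ccc23)CC1`, differs from compound 2 in one place: 3,5-dichlorophenyl in place of 3,4-difluorophenyl on a nitrogen on an aromatic ring. Going by the values given here, the one measured step that bears on this is the aryl swap a 1.8-fold lower number from compound 1 to compound 2 (0.24 log units; within the scatter), which was small. Among the compounds with values here, no measured pair shows a change of halogen or of substitution pattern on that aryl group. On this basis no step beyond the scatter is expected for compound 3 in this assay, so the expected step is a 1.1-fold lower number from compound 2 to compound 3 (0.03 log units; within the scatter). Compound 3 is therefore estimated at 1000 nM, with a range from 400 nM to 2500 nM.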

Compound 3, concentration for 50% growth inhibition: 1670 nM
Compound 3: the middle estimate sits 1.7-fold (0.22 log units) below what was measured; low and high end bracket the measured number.
By their numbers in this assay, from the lowest: compounds 2, 3 and 1 (each within the scatter of the next).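

In this assay, replacing 3,4-difluorophenyl with 3,5-dichlorophenyl on the nitrogen gives a small step (a 1.5-fold higher number from compound 2 to compound 3 (0.19 log units; within the scatter)), and replacing 4-isopropylphenyl with 3,5-dichlorophenyl gives another (a 1.1-fold lower number from compound 1 to compound 3 (0.05 log units; within the scatter)). All three aryl groups tested at this place therefore give numbers that cannot be told apart, so this place has so far shown no measurable preference among these substituted phenyl groups, although the halogen and its placing on the ring change together in the newest step, so their separate contributions cannot be read. Nothing available here offers an explanation for this result.

The compounds shown leave open whether a different kind of group on this nitrogen, such as a pyridyl ring, a benzyl group or a phenyl carrying a carboxylic acid, would move the number beyond the scatter. They also leave open what a morpholine in place of the methylpiperazine, or a shorter chain to it, would do.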